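Extending the acid chain on the shared core

A few compounds are considered here, and "the series" means these few. Any claim that something is new, unique, unknown or untested is made for them only; others in the source may bear on it.

Compound 2, with structure `CC(CC(=O)O)N1Cc2ccc(NC(=O)c3ccc(C4CCNCC4)cc3)cc2C1=O`, is the stronger of the two measured compounds in a functional assay on a cell-free system (Platelet, plasma, Homo sapiens) for inhibition (on this read-out lower numbers stand for stronger inhibition and higher numbers for weaker inhibition), giving 6200 nM. Going by the values given here, compound 1, with structure `O=C(O)CN1Cc2ccc(NC(=O)c3ccc(C4CCNCC4)cc3)cc2C1=O`, gives 24000 nM in this assay, and the only measured step, a 3.9-fold lower number from compound 1 to compound 2 (0.59 log units; beyond the scatter), shows a gain when the acid-bearing chain on the ring nitrogen grows by one carbon.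

Compound 3, with structure `O=C(O)CCCN1Cc2ccc(NC(=O)c3ccc(C4CCNCC4)cc3)cc2C1=O`, has not yet been measured in this assay. It differs from compound 2 by 3-carboxypropyl in place of 1-(carboxymethyl)ethyl on an amide-type nitrogen in a ring. Among the compounds with values here, the new chain again places the acid further from the ring nitrogen, but it also loses the branch that compound 2 carries, and no measured pair speaks to that branch alone.

Within the data shown here, only the step from compound 1 to compound 2 bears on this change, and it was modest. Taking it as the guide, a small gain or no change beyond the scatter is expected, so compound 3 is estimated to sit around 4000 nM, within a range from 1500 nM to 12000 nM. The step from compound 2 to compound 3 is thus expected to be a 1.6-fold lower number from compound 2 to compound 3 (0.19 log units; within the scatter).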

Compound 3, half-maximal inhibitory concentration: 410000 nM
Compound 3: middle estimate off by 100-fold (2.01 log units), on the low side; measured number outside the range, above it.
By their numbers in this assay, from the lowest: compound 2; then compound 1; then compound 3.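

In this assay the chains of compound 2 and compound 3 hold the same atoms joined differently, yet replacing 1-(carboxymethyl)ethyl with 3-carboxypropyl on the amide-type nitrogen gives a 66-fold higher number from compound 2 to compound 3 (1.82 log units; beyond the scatter) at this position, so how the chain is put together matters and not just what it contains. Compared with the shorter carboxymethyl chain, the same 3-carboxypropyl chain gives a 17-fold higher number from compound 1 to compound 3 (1.23 log units; beyond the scatter) and thus shows that a longer acid chain does not by itself bring a gain, which means the earlier improvement with compound 2 cannot be read as an effect of length alone. Nothing available here explains why these two chains of equal atom content differ so widely.

Going by these compounds, what remains open is whether the branch itself or the distance of the acid from the ring nitrogen drives the difference, since compound 2 and compound 3 differ in how both are arranged. A straight 2-carboxyethyl chain on the same nitrogen would help separate the two, and a branched 1-carboxyethyl chain would show whether a branch still goes with the stronger number when the carboxylic acid sits closer to that nitrogen.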